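Swapping a Benzyl Group for Methoxyphenyl: Solubility Outlook

The compounds below may be only part of what the source reports. "The series", "measured", "known", "first", "only" and "open" are said of these compounds alone.

Compound 1, `COc1ccc(F)cc1CNCCCNc1ccnc2cc(Cc3ccc(F)cc3)ccc12`: 4200 nM
Compound 2, `COc1ccc(-c2ccc3c(NCCCNCc4ccco4)ccnc3c2)cc1`: 32000 nM
Compound 3, `COc1ccc(F)cc1CNCCCNc1ccnc2cc(Cc3ccc(F)cc3Cl)ccc12`: 4200 nM

In a physicochemical assay for solubility, with a stated time of 18 h, at pH 7.4 (on this read-out lower numbers stand for lower solubility and higher numbers for higher solubility), compound 3 gives 4200 nM, level with compound 1 and well below compound 2. Within the data shown here, the only measured step, no change at the digits printed from compound 1 to compound 3 (within the scatter), shows that chloro in place of hydrogen on an aromatic carbon leaves the number unchanged. Compound 4, `COc1ccc(-c2ccc3c(NCCCNCc4cc(F)ccc4OC)ccnc3c2)cc1`, differs from compound 3 by 4-methoxyphenyl in place of 2-chloro-4-fluorobenzyl on an aromatic carbon. Among the measured compounds shown here, no measured step covers this exchange directly. Compound 2, however, carries the same 4-methoxyphenyl group on its core and gives 32000 nM, clearly above compound 3. Compound 4 is therefore expected to move upward, a 2.9-fold higher number from compound 3 to compound 4 (0.46 log units; beyond the scatter), landing between the two. The estimate for compound 4 is 12000 nM, with an expected range from 4000 nM to 40000 nM.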

Compound 4, solubility: 32000 nM
For compound 4 the middle estimate is 2.7-fold (0.43 log units) below the measured one; the range from low to high includes it.
By their numbers in this assay, from the lowest: compounds 1 and 3 (each within the scatter of the next); then compounds 2 and 4 (each within the scatter of the next).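

In this assay the exchange at this aromatic carbon gives a 7.6-fold higher number from compound 3 to compound 4 (0.88 log units; beyond the scatter) with 2-chloro-4-fluorobenzyl leaving and a 7.6-fold higher number from compound 1 to compound 4 (0.88 log units; beyond the scatter) with 4-fluorobenzyl leaving, so the chloro makes no difference to the size of the rise. With 4-methoxyphenyl in place, the other end of the molecule does not register either: no change at the digits printed from compound 2 to compound 4 (within the scatter) comes with 5-fluoro-2-methoxyphenyl in place of furan-2-yl. On these data alone, whether the rise belongs to the methoxy group or to the loss of the benzyl link stays open, as does the outcome with an amine or a carboxylic acid on that ring. Nothing shown gives a reason for the rise.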